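From carbamoyl to tert-butyl on the shared core

This account rests on a few compounds, and the source may have more. Where it says the series, first, only, none or still open, it means among the compounds named here.

Measured compounds and their values:
compound 1 `Cc1cc(NC(=O)Nc2cccc(C(N)=O)c2)c2ccccc2n1` | > 25000 nM
compound 2 `Cc1cc(NC(=O)Nc2ccc(C(=O)O)cc2)c2ccccc2n1` | > 25000 nM

In an ADME assay on HEK293 cells (Homo sapiens) for cytotoxicity, with a stated time of 72 h (a higher number here means that more compound is needed for the effect, a lower number that less compound is needed), compound 1 gives > 25000 nM as a limit of the assay, not a number. Compound 2 gives > 25000 nM as a limit too. Compound 1 therefore stands at the limit of > 25000 nM in this assay, at which 2 of the 2 values shown sit, and has no number of its own.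

Compound 3 `Cc1cc(NC(=O)Nc2cccc(C(C)(C)C)c2)c2ccccc2n1` has not yet been measured. It carries tert-butyl in place of carbamoyl on an aromatic carbon, meta to a large group (tert-butyl in place of carbamoyl on an aromatic carbon). Among the compounds with values here, no measured step between compounds bears on this change. A modest move toward less compound needed is expected, though it may stay within the scatter. The expected step (an at least 1.3-fold lower number from compound 1 to compound 3 (0.14 log units; that floor lies within the scatter)) is only an estimate. For compound 3 the estimated value is 18000 nM, with a range from 6000 nM to 25000 nM, and the assay may again report only a limit.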

Compound 3, half-maximal effective concentration: > 25000 nM
Compound 3 gave a limit, no number (the forecaster's own chance of this, stated with the estimate: 55%); at least 1.3-fold (0.14 log units) between middle value and limit.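

In this assay compound 3 gives > 25000 nM, a limit of the assay and not a number. Within the data shown here, compound 1 also gives only a limit, so no step from compound 1 to compound 3 can be read. The compounds shown leave open which change on the shared core, if any, would yield an actual number, with every value so far at one point: the limit of > 25000 nM in this assay, at which 3 of the 3 values shown sit.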